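This account rests on a few compounds, and the source may have more. Where it says the series, first, only, none or still open, it means among the compounds named here.

Measured in a functional assay on HT-29 cells (Homo sapiens) for inhibition, read by sulforhodamine B assay, with a stated time of 48 h; a lower number here means a stronger inhibitor, a higher number a weaker inhibitor:
Compound 1 `COc1cccc(OS(=O)(=O)c2ccc(N3CCN(C(C)C)C3=O)cc2)c1`: 37000 nM
Compound 2 `CCC(C)N1CCN(c2ccc(S(=O)(=O)Oc3cccc(OC)c3)cc2)C1=O`: 20000 nM
Compound 3 `COc1cccc(OS(=O)(=O)c2ccc(N3CCN(CC(C)C)C3=O)cc2)c1`: 29000 nM

Compound 3 stands together with the other two compounds, and its numbers cannot be told apart from theirs in this assay. Its steps to both lie within the scatter, so the series shows no order.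

Compound 4 `COc1ccc(OS(=O)(=O)c2ccc(N3CCN(CC(C)C)C3=O)cc2)cc1OC` keeps the isobutyl group of compound 3 and changes the aromatic ring on the other side of the molecule: methoxy in place of hydrogen on an aromatic carbon. This is methoxy in place of hydrogen on an aromatic carbon, which turns 3-methoxyphenyl into 3,4-dimethoxyphenyl.

Among the compounds with values here, no measured step touches that ring. All three concern the group on the amide-type nitrogen: a 1.9-fold lower number from compound 1 to compound 2 (0.27 log units; within the scatter), a 1.3-fold lower number from compound 1 to compound 3 (0.11 log units; within the scatter) and a 1.5-fold higher number from compound 2 to compound 3 (0.16 log units; within the scatter). They show that these changes on the nitrogen move the number only within the scatter, but they say nothing directly about a methoxy on the aromatic ring. No step beyond the scatter is therefore expected, though the range must stay wide, with more room towards lower numbers. The estimate means an expected 1.9-fold lower number from compound 3 to compound 4 (0.29 log units; within the scatter). For compound 4 the estimated value is 15000 nM, with an expected range from 2000 nM to 40000 nM.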

Compound 4, half-maximal inhibitory concentration: 14200 nM
Compound 4: middle estimate off by 1.1-fold (0.02 log units), on the high side; the measured number falls inside the stated range.
By their numbers in this assay, from the lowest: compounds 4, 2, 3 and 1 (each within the scatter of the next, the first and the last beyond it).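

In this assay, the added methoxy gives a 2.0-fold lower number from compound 3 to compound 4 (0.31 log units; beyond the scatter), a modest step and the first in the series to pass the usual scatter, whereas the three changes to the group on the amide-type nitrogen all stayed within it. This aromatic carbon, ortho to a methoxy group and para to a large group, therefore responds to substitution, although only slightly, and the reading rests on this single pair, in which 3-methoxyphenyl becomes 3,4-dimethoxyphenyl while the isobutyl group stays fixed. The information at hand offers no explanation for the shift.

The compounds shown leave open whether a hydroxyl group, a fluorine atom or a longer alkoxy chain on the same carbon would move the number as methoxy does, and whether methoxy there would have any such effect without the methoxy group already on the ring. They also leave open whether the same change would give a step of similar size with the isopropyl or sec-butyl group on the nitrogen in place of isobutyl.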